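The compounds below may be only part of what the source reports. "The series", "measured", "known", "first", "only" and "open" are said of these compounds alone.

The study asks how strongly each compound holds back the growth of cultured cells, read in a functional assay on ONS-76 cells (Homo sapiens) for cytotoxicity, read by MTT assay, with a stated time of 72 h; on this read-out higher numbers stand for weaker inhibition and lower numbers for stronger inhibition. Compound 1 `COc1cc(NC(=O)Nc2ccc([N+](=O)[O-])cc2)cc(OC)c1OC` gives 35000 nM in this assay. Compound 2 `COc1cc(N(C)C(=O)N(C)c2ccc([N+](=O)[O-])cc2)cc(OC)c1OC` is a close relative of compound 1. In this assay compound 2 reaches only the limit >= 125000 nM. Compound 3 `COc1cc(N(C)C(=O)c2ccccc2)cc(OC)c1OC` drops the nitro-bearing ring of the first two compounds and keeps the shared core on one side. In this assay compound 3 likewise comes back at the limit >= 125000 nM. So compound 3 stands at the weak end of everything shown here, alongside compound 2: the limit of >= 125000 nM in this assay, at which 2 of the 3 values shown sit, and only compound 1 yields an actual number.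

Compound 4 `COc1cc(N(C)C(=O)c2cccc(F)c2)cc(OC)c1OC` differs from compound 3 in one place: fluoro in place of hydrogen on an aromatic carbon. Read one bond further out, the change is phenyl to 3-fluorophenyl. Going by the values given here, no pair of measured compounds shows what a single change of this kind does in this assay, so there is nothing to lean on beyond the structures themselves. The step of a number no higher from compound 3 to compound 4 (the limit leaves the size open) is expected to stay within the usual scatter, in no particular direction. Compound 4 is therefore estimated at 125000 nM, with a range from 35000 nM to 400000 nM, and most likely it too will be reported only as a limit.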

Compound 4, half-maximal inhibitory concentration: >= 125000 nM
Compound 4 was reported as a limit (the forecaster's own chance of this, stated with the estimate: 70%); the middle value sits exactly at the limit.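

Going by these compounds alone, compound 3 and compound 4 both come back in this assay as limits and not as actual numbers, so no step from one to the other can be read. The compounds shown leave open whether fluoro in place of hydrogen on an aromatic carbon changes the inhibition of cell growth at all.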